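The compounds below may be only part of what the source reports. "The series", "measured", "known", "first", "only" and "open" are said of these compounds alone.

Measured compounds:
compound 1 `CC1CCCC(C(=O)N2CC(c3nc(-c4cccc(Cl)c4)no3)C2)C1`, 410 nM
compound 2 `Cc1cccc(S(=O)(=O)N2CC(c3nc(-c4cccc(Cl)c4)no3)C2)c1`, > 10000 nM

For the measured compounds named here, in an assay on HEK293 cells for positive allosteric modulation of metabotropic glutamate receptor 5 (Homo sapiens), read by FLIPR (on this read-out lower numbers stand for an effect already at smaller amounts and higher numbers for an effect only at larger amounts of compound), compound 1 gives 410 nM, the only numerical value in the set. Compound 2 returns > 10000 nM, which is a limit of the assay and not a number, as the limit of > 10000 nM in this assay, at which 1 of the 2 values shown sits. Compound 3 `CC1CCN(C(=O)N2CC(c3nc(-c4cccc(Cl)c4)no3)C2)CC1` differs from compound 1 by 4-methylpiperidin-1-yl in place of 3-methylcyclohexyl on a carbonyl carbon. Going by the values given here, no measured pair of this kind exists in the set, so the size of the step is open; a moderate weakening beyond the scatter is expected, with a 2.2-fold higher number from compound 1 to compound 3 (0.34 log units; beyond the scatter). Compound 3 is thus estimated at 900 nM, within 250 nM to 3500 nM.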

Compound 3, half-maximal effective concentration: 865 nM
Compound 3: middle estimate off by 1.0-fold (0.02 log units), on the high side, and the stated range covers the measured number.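

In this assay, 4-methylpiperidin-1-yl in place of 3-methylcyclohexyl on a carbonyl carbon gives a 2.1-fold higher number from compound 1 to compound 3 (0.32 log units; beyond the scatter), so a measurable effect survives at this position with a ring holding a hetero atom. This single step changes the ring atoms and the methyl-bearing ring position together, and the two changes cannot be separated here. No measured property on hand accounts for the size of the step.

Open, on these data alone, is how a morpholine ring, an unsubstituted piperidine or an open-chain amine would read on the same carbonyl carbon.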